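Working notes: heptyl to butoxy on the shared core

This account rests on a few compounds, and the source may have more. Where it says the series, first, only, none or still open, it means among the compounds named here.

Values in a functional assay on MCF7 cells (Homo sapiens) for antiproliferative activity, read by sulforhodamine B assay, with a stated time of 48 h (a higher number here means a weaker inhibitor, a lower number a stronger inhibitor), so far
compound 1 `CCCCc1ccc(NS(=O)(=O)c2ccc(N3CCNC3=O)cc2)cc1` gives 770 nM
compound 2 `Cc1ccc(NS(=O)(=O)c2ccc(N3CCNC3=O)cc2)cc1C` gives 230 nM
compound 3 `CCCCCCCc1ccc(NS(=O)(=O)c2ccc(N3CCNC3=O)cc2)cc1` gives > 1000 nM as a limit

Compound 3 has no number, only the limit of > 1000 nM in this assay, at which 1 of the 3 values shown sits, and that is a limit. In compound 4 `CCCCOc1ccc(NS(=O)(=O)c2ccc(N3CCNC3=O)cc2)cc1` the change is butoxy in place of heptyl on an aromatic carbon and the rest of the structure is kept. Going by the values given here, the only measured step that bears on this is an at least 1.2-fold higher number from compound 1 to compound 3 (0.11 log units; that floor lies within the scatter) and it sets no firm size. Compound 1 is the closest measured chain, at 770 nM in this assay and compound 4 is expected to read near it. A lower number is expected, an estimated at least 1.6-fold lower number from compound 3 to compound 4 (0.22 log units; that floor lies within the scatter) on this reasoning, though the limit leaves its size open. For compound 4 the estimate is 600 nM with 200 nM to 1800 nM as the expected range.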

Compound 4, half-maximal inhibitory concentration: 870 nM
Estimate against measurement, compound 4: 1.5-fold (0.16 log units) below; the measured number falls inside the stated range.
By their numbers in this assay, from the lowest: compound 2; then compounds 1 and 4 (each within the scatter of the next). At a limit, above all of these: compound 3.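

Butoxy and butyl on this aromatic carbon read alike in this assay, with a 1.1-fold higher number from compound 1 to compound 4 (0.05 log units; within the scatter). Against heptyl the result is an at least 1.1-fold lower number from compound 3 to compound 4 (0.06 log units; that floor lies within the scatter). Compound 3 carries a limit and not a number: the limit of > 1000 nM in this assay, at which 1 of the 4 values shown sits.

Open, from the compounds shown here alone, is how a propoxy chain, a hexyl chain or a butyl chain ending in an amine would read on this aromatic carbon. Also open, going by these compounds, is whether the reading moves at all between butyl and heptyl, given that heptyl has only a limit.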